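Cytotoxicity of a quinolone ether series: acetyl to carboxy

This account rests on a few compounds, and the source may have more. Where it says the series, first, only, none or still open, it means among the compounds named here.

Working notes on a small set sharing one core. Compound 1 `CCCCc1cc2c(=O)c(C#N)c[nH]c2cc1OCCOc1ccccc1` carries a nitrile on the core. In an ADME assay on J774 cells (Mus musculus) for cytotoxicity (on this read-out lower numbers stand for an effect already at smaller amounts and higher numbers for an effect only at larger amounts of compound), compound 1 gives > 20000 nM, which is a limit of the assay and not a number. Compound 2 `CCCCc1cc2c(=O)c(C(C)=O)c[nH]c2cc1OCCOc1ccccc1` carries an acetyl instead; in this assay compound 2 gives "not determined" (no result reported), so no number stands for it. Among the measured compounds shown here, the only value shown for the set is therefore summarised as the limit of > 20000 nM in this assay, at which 1 of the 2 values shown sits. Compound 3 `CCCCc1cc2c(=O)c(C(=O)O)c[nH]c2cc1OCCOc1ccccc1` differs from compound 2 by hydroxy in place of methyl on a carbonyl carbon. For the measured compounds named here, no step between measured compounds is available to size this change; the expectation in this assay is a step of no more than the usual scatter, in no fixed direction. Compound 3 is therefore expected to read near 30000 nM, within 10000 nM to 100000 nM, and most likely again as a limit rather than a number.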

Compound 3, half-maximal effective concentration: > 20000 nM
Compound 3 ended at the assay's limit (the forecaster's own chance of this, stated with the estimate: 80%); the middle value does not contradict the limit.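

No step can be read from compound 1 to compound 3 in this assay: both readings are limits of the assay, not numbers, and compound 2 has no number. The compounds shown leave open whether nitrile, acetyl or carboxy on the shared core differ in cytotoxicity at all.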